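From methylamino to formyl on a shared core

This account rests on a few compounds, and the source may have more. Where it says the series, first, only, none or still open, it means among the compounds named here.

Compound 1 (`N#Cc1cc(=O)[nH]c(=O)n1[C@@H]1O[C@H](CO)[C@@H](O)[C@H]1O`) gives > 50000 nM in a functional assay on LOX cells (Homo sapiens) for antiproliferative activity, read by WST assay, with a stated time of 3 days (a higher number here means a weaker inhibitor, a lower number a stronger inhibitor), as its result, which is a limit and not a number. Compound 2 (`O=c1cc(I)n([C@@H]2O[C@H](CO)[C@@H](O)[C@H]2O)c(=O)[nH]1`) gives > 50000 nM in this assay as its result, again only a limit. Compound 3 (`CNc1cc(=O)[nH]c(=O)n1[C@@H]1O[C@H](CO)[C@@H](O)[C@H]1O`) gives > 50000 nM in this assay as its result, also a limit, so it has no exact place among these compounds.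

All three results stand together in the limit of > 50000 nM in this assay, at which 3 of the 3 values shown sit, and no change so far has a readable size. There is a step that the two limits leave unreadable from compound 1 to compound 2 and then a step that the two limits leave unreadable from compound 1 to compound 3 and finally a step that the two limits leave unreadable from compound 2 to compound 3 to complete the set.

Compound 4 (`O=Cc1cc(=O)[nH]c(=O)n1[C@@H]1O[C@H](CO)[C@@H](O)[C@H]1O`) has formyl in place of methylamino on an aromatic carbon is the full change. Judging from the limit of > 50000 nM in this assay, at which 3 of the 3 values shown sit, alone, no step beyond the usual scatter is expected, in either direction, and the estimated change is a number no higher from compound 3 to compound 4 (the limit leaves the size open) on that basis. Compound 4 is estimated at 50000 nM in this assay with an expected range from 20000 nM to 100000 nM as its likely span.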

Compound 4, half-maximal inhibitory concentration: > 50000 nM
Compound 4: a limit, no number; the forecaster's own chance of this, stated with the estimate: 80%; the middle value sits exactly at the limit.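

Compound 4 gives > 50000 nM in this assay, a limit and not a number. No step among compound 1, compound 2, compound 3 and compound 4 can be read: the limit of > 50000 nM in this assay, at which 4 of the 4 values shown sit.

The compounds shown leave open how far these four differ, and whether any group at this place on the shared core gives a measurable value.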